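A few compounds are considered here, and "the series" means these few. Any claim that something is new, unique, unknown or untested is made for them only; others in the source may bear on it.

Working notes on the series. Of the compounds shown here, three have been read in a functional assay on the whole organism with Rattus norvegicus as the target; a lower number here means that less compound is needed, a higher number that more compound is needed for the effect. Compound 1 `Nc1nc2ccc(I)cc2s1` reads > 10 mg/kg, which is a limit of the assay. Compound 2 `CCC(C)(C)c1ccc2nc(N)sc2c1` reads > 10 mg/kg, which is also a limit. For the measured compounds named here, compound 3 `CCS(=O)(=O)CCn1c(=N)sc2cc(C(F)(F)C(F)(F)F)ccc21` gives 2.1 mg/kg, the only actual number in the set, so it cannot be placed by size against either of the others.

The next compound is compound 4 `CCS(=O)(=O)CCn1c(=N)sc2cc(OC(F)(F)C(F)(F)F)ccc21`. The structural change from compound 3 is 1,1,2,2,2-pentafluoroethoxy in place of 1,1,2,2,2-pentafluoroethyl on an aromatic carbon. In short, 1,1,2,2,2-pentafluoroethoxy stands in place of 1,1,2,2,2-pentafluoroethyl on an aromatic carbon.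

One measured step also exchanges a group on an aromatic carbon: a step that the two limits leave unreadable from compound 1 to compound 2. That step has no readable size because of the limit of > 10 mg/kg in this assay, at which 2 of the 3 values shown sit, and it involves neither of the groups in question here. It gives no size to carry over to the present change. Going by the values given here, no step beyond the scatter is therefore expected in this assay, and no direction is predicted, the only anchor being compound 3 at 2.1 mg/kg. The expected change is no change at the digits printed from compound 3 to compound 4 (within the scatter). For compound 4 the estimated value is 2.1 mg/kg, with an expected range of 0.7 mg/kg to 6.5 mg/kg. Among the compounds with values here, only one number supports this estimate, so the range is kept wide.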

Compound 4, dose for half-maximal effect: 2.6 mg/kg
Compound 4: the middle estimate sits 1.2-fold (0.09 log units) below what was measured, and the stated range covers the measured number.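

In this assay, for the compounds shown here, the exchange of 1,1,2,2,2-pentafluoroethyl for 1,1,2,2,2-pentafluoroethoxy gives a 1.2-fold higher number from compound 3 to compound 4 (0.09 log units; within the scatter) and so supplies the first step on an aromatic carbon that has a readable size. At this place on the six-membered aromatic ring, the entering oxygen and its one hydrogen-bond acceptor leave the read-out within the scatter, so the two groups cannot be told apart on this measure when the rest of the structure is held constant. The earlier exchange on an aromatic carbon could not show this, as the step from compound 1 to compound 2 has no readable size: the limit of > 10 mg/kg in this assay, at which 2 of the 4 values shown sit.

Still open, as far as these compounds go, is whether the read-out holds when a quite different group stands at this place, such as an amine, a carboxylic acid or a longer perfluoroalkyl chain. Also open, from the compounds shown here alone, is how much the group at this place contributes compared with the rest of the structure, since compound 3 and compound 4 each differ from compound 1 and compound 2 in more than one place.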